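Opening the ring: from compound 3 to compound 4

The compounds below may be only part of what the source reports. "The series", "measured", "known", "first", "only" and "open" are said of these compounds alone.

Measured so far in a physicochemical assay for lipophilicity; on this read-out higher numbers stand for higher lipophilicity and lower numbers for lower lipophilicity
- compound 1 `COc1ccc(C(=O)N(Cc2csc(-c3ccccc3)n2)C2CCCCC2)cc1` gives 4.6
- compound 2 `COc1ccc(C(=O)N(Cc2cc(-c3ccccc3)on2)C2CCCCC2)cc1` gives 4.2
- compound 3 `O=C(CN(C(=O)c1ccc(-c2ccccn2)cc1)C1CCCOC1)Nc1cc(F)cc(F)c1` gives 2.7

Compound 3 at 2.7 is the lowest of the three numbers. Compound 2 at 4.2 is its nearest neighbour and compound 1 at 4.6 its furthest, with both gaps beyond the usual scatter.

The next compound to be read is compound 4 `COCC(C)N(CC(=O)Nc1cc(F)cc(F)c1)C(=O)c1ccc(-c2ccccn2)cc1` which differs from compound 3 in one place. It has 1-(methoxymethyl)ethyl in place of oxan-3-yl on an amide-type nitrogen and the ring of that group is gone.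

Going by the values given here, no two measured compounds differ in one place, so the series offers no direct precedent for this change. Compounds 1 and 2 say little about it, and the expectation rests on the structural change alone. The two groups are close in size and neither carries a net charge. In this assay no step beyond the scatter is therefore expected, with only a slight lean upward. The expected change is a number 0.10 log units higher from compound 3 to compound 4 (within the scatter) and that would lie within the usual scatter. The estimated value for compound 4 is 2.8 within an expected range of 2.4 to 3.2 on this scale.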

Compound 4, distribution coefficient: 3
Compound 4: middle estimate off by 0.20 log units, on the low side, and the stated range covers the measured number.
By their numbers in this assay, from the lowest: compounds 3 and 4 (each within the scatter of the next); then compound 2; then compound 1.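

In this assay, going by these compounds alone, 1-(methoxymethyl)ethyl in place of oxan-3-yl on the amide-type nitrogen gives a number 0.30 log units higher from compound 3 to compound 4 (within the scatter), and this is the first comparison in which only one place differs. At this position, then, the ring of oxan-3-yl can be opened without a step beyond the scatter on this read-out, with the hydrogen-bond acceptor count unchanged and neither group carrying a net charge. No measured evidence at hand accounts for the closeness of the two values, so the pair records an outcome and gives no explanation for it.

Within the data shown here, the pair covers only two uncharged groups, each with one ether oxygen, so the values that an amine, a carboxylic acid or a longer alkyl chain would give on this nitrogen remain open. Also open, on these data alone, is whether the same ring opening would give a similar step on another core, as compound 1 and compound 2 differ from compound 3 in more than one place and offer no comparison for this change.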